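Side-chain variation at the amide-bearing carbon

The compounds below may be only part of what the source reports. "The series", "measured", "known", "first", "only" and "open" are said of these compounds alone.

Compound 3 `CC(C)[C@H](NC(=O)CN(c1nc(Cl)nc2[nH]cnc12)C1CC1)C(=O)OCc1ccccc1` gives 17.9% in a functional assay on the whole organism (Tail, strain ICR) with Mus musculus as the target, in the tail flick test, with a stated time of 150 min, at a dose of 25 umol/kg by the oral route (on this read-out lower numbers stand for a weaker effect and higher numbers for a stronger effect at the one dose given), the highest of the three numbers; compound 2 `NCCCC[C@H](NC(=O)CN(c1nc(Cl)nc2[nH]cnc12)C1CC1)C(=O)OCc1ccccc1` gives 9.88% and compound 1 `O=C(CN(c1nc(Cl)nc2[nH]cnc12)C1CC1)N[C@@H](CC(=O)OCc1ccccc1)C(=O)OCc1ccccc1` gives 6.68%. The step of a number 8 percentage points higher from compound 2 to compound 3 (within the scatter) lies within the scatter, the step of a number 11.2 percentage points higher from compound 1 to compound 3 (beyond the scatter) beyond it, and a number 3.2 percentage points higher from compound 1 to compound 2 (within the scatter) stays within the scatter. Compound 4 `NC(=O)C[C@H](NC(=O)CN(c1nc(Cl)nc2[nH]cnc12)C1CC1)C(=O)OCc1ccccc1` carries the change (carbamoylmethyl in place of isopropyl on a saturated chain carbon bound to an amide-type nitrogen and a carbonyl carbon). The two side chains that bring a hydrogen-bond donor or acceptor gave lower numbers than compound 3, so a downward step is expected for compound 4, of a size comparable to a number 11.2 percentage points higher from compound 1 to compound 3 (beyond the scatter) or a number 8 percentage points higher from compound 2 to compound 3 (within the scatter) reversed. For compound 4 the expected step is a number 8.9 percentage points lower from compound 3 to compound 4 (within the scatter). Compound 4 is therefore estimated at 9%, between 2% and 18%.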

Compound 4, a percentage reported as activity, at one dose (the size of the read-out at that dose, not a potency): 13.5%
For compound 4 the middle estimate is 4.5 percentage points below the measured one; the measured number falls inside the stated range.
By their numbers in this assay, from the lowest: compounds 1, 2, 4 and 3 (each within the scatter of the next, the first and the last beyond it).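

In this assay, carbamoylmethyl on this saturated chain carbon gives a number 4.4 percentage points lower from compound 3 to compound 4 (within the scatter) and so cannot be told apart from isopropyl, although it brings a hydrogen-bond donor and acceptor. The comparisons with the other side chains, a number 3.6 percentage points higher from compound 2 to compound 4 (within the scatter) and a number 6.8 percentage points higher from compound 1 to compound 4 (within the scatter), also stay within the scatter, so compound 4 is not separated from any of the three earlier compounds. No measurement given here bears on the reason for these steps. Open, going by these compounds, is how a carboxylic acid or a plain methyl at this carbon would compare with isopropyl.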